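A few compounds are considered here, and "the series" means these few. Any claim that something is new, unique, unknown or untested is made for them only; others in the source may bear on it.

Measured so far: compound 1 `C[C@H](Nc1nc(N)nc(N)c1C#N)c1nn(-c2cccc(S(C)(=O)=O)c2)c2cc(F)ccc12` with 36%; compound 2 `Cc1ccc2c(c1)c([C@H](C)Nc1ncnc3[nH]cnc13)nn2-c1cccnc1` with 8%; compound 3 `C[C@H](Nc1nc(N)nc(N)c1C#N)c1nn(-c2cccnc2)c2cc(C(F)(F)F)ccc12` with 69%.

In a functional assay on Hep 3B2 cells (Homo sapiens) for inhibition, read by sulforhodamine B assay, with a stated time of 72 h, tested at 10 uM (a higher number here means more inhibition at the concentration tested (going by the name of the read-out), a lower number less inhibition), compound 1 gives 36%, the second highest of the three numbers: compound 2 lies beyond the scatter below it, and compound 3 lies beyond the scatter above it. Compound 4 `C[C@H](Nc1ncnc2[nH]cnc12)c1nn(-c2cccc(S(C)(=O)=O)c2)c2cc(F)ccc12` has not yet been measured. It differs from compound 1 in one place: a group of 9 heavy atoms (5 carbon, 4 nitrogen; one five-membered aromatic ring with 2 hetero atoms, one six-membered aromatic ring with 2 hetero atoms) in place of a group of 10 heavy atoms (5 carbon, 5 nitrogen; one six-membered aromatic ring with 2 hetero atoms), on an amine nitrogen. For the measured compounds named here, no step between measured compounds carries this change. The group that enters compound 4 is also the group attached at the amine nitrogen of compound 2, which in this assay gives 8%, although compound 2 also differs elsewhere. A drop beyond the scatter is therefore expected, with a number 21 percentage points lower from compound 1 to compound 4 (beyond the scatter) as the estimated step. Compound 4 is estimated at 15%, between 0% and 40%.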

Compound 4, a percentage reported as inhibition, at one concentration (the size of the read-out at that concentration, not a potency): 11%
Compound 4: the middle estimate sits 4 percentage points above what was measured; measured number inside the range.
By their numbers in this assay, from the lowest: compounds 2 and 4 (each within the scatter of the next); then compound 1; then compound 3.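

In this assay the change on the amine nitrogen gives a number 25 percentage points lower from compound 1 to compound 4 (beyond the scatter) while the rest of the structure stays the same. For the compounds shown here, this is the first comparison that isolates this position, and it ties higher inhibition to the 2,6-diamino-5-cyanopyrimidin-4-yl group rather than to the group with a five-membered and a six-membered aromatic ring. No measurement offered here explains the step. As far as these compounds go, it remains open which part of the departing group matters, for instance whether a carboxamide in place of the nitrile would keep the inhibition. From the compounds shown here alone, whether the step recurs with other groups elsewhere on the core is also open.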